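The source may report more compounds than this note shows. Statements on the series, on what has been measured and on what is new or still open speak of the compounds shown alone.

Measured so far:
compound 1 `Cc1nc2c(Br)c(Br)c(Br)c(Br)c2n1CCCC#N`, in a functional assay on MCF7 cells (Homo sapiens) for cytotoxicity, read by MTT assay, with a stated time of 24 h, tested at 20 uM (on this read-out lower numbers stand for a stronger effect and higher numbers for a weaker effect at the one concentration tested), giving 56%
compound 2 `N#CCCn1cnc2c(Br)c(Br)c(Br)c(Br)c21`, in this assay giving 72%

Compound 2 has the higher of the two numbers in this assay; compound 1 sits a stretch below it, beyond the scatter. Compound 3 `N#CCCCn1cnc2c(Br)c(Br)c(Br)c(Br)c21` differs from compound 2 only as cyanomethyl in place of cyano on a saturated chain carbon, two bonds along the chain from an aromatic nitrogen. Going by the values given here, no measured pair shows what such a change does here, so the expectation rests on the weak footing of compound 2 alone. The step is expected to be small, none beyond the scatter: a number 4 percentage points lower from compound 2 to compound 3 (within the scatter) in this assay. Compound 3 is therefore estimated at 68%, with a range from 52% to 84%.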

Compound 3, a percentage reported as activity, at one concentration (the size of the read-out at that concentration, not a potency): 70%
Compound 3: the middle estimate sits 2 percentage points below what was measured; the measured number falls inside the stated range.
By their numbers in this assay, from the lowest: compound 1; then compounds 3 and 2 (each within the scatter of the next).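

In this assay the change to cyanomethyl in place of cyano on a saturated chain carbon, two bonds along the chain from an aromatic nitrogen, gives a number 2 percentage points lower from compound 2 to compound 3 (within the scatter) and so does not separate 2-cyanoethyl from 3-cyanopropyl at this position. Going by these compounds alone, with the 3-cyanopropyl chain shared, hydrogen in place of methyl on an aromatic carbon gives a number 14 percentage points higher from compound 1 to compound 3 (beyond the scatter) as the first single-place reading of that methyl. No measured evidence bears on the reason for either step. Going by these compounds, a longer chain, or an amine or a carboxylic acid in place of the nitrile, remains open on the shared core.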